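Ketooxazole series: trifluoroacetyl in place of the aryl substituent

This account rests on a few compounds, and the source may have more. Where it says the series, first, only, none or still open, it means among the compounds named here.

Measured so far:
compound 1, `COC(=O)c1cccc(-c2cnc(C(=O)CCCCCCc3ccccc3)o2)c1`: 12 nM
compound 2, `COc1ccc(-c2cnc(C(=O)CCCCCCc3ccccc3)o2)cc1`: 100 nM

In an assay (Rattus norvegicus) for inhibition of Fatty-acid amide hydrolase 1 (Homo sapiens) (on this read-out lower numbers stand for stronger inhibition and higher numbers for weaker inhibition), compound 2 gives 100 nM, the higher of the two numbers recorded; compound 1 gives 12 nM, a gap beyond the usual scatter. Within the data shown here, no step between the two is computed here, since they differ at more than one place.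

Compound 3, `O=C(CCCCCCc1ccccc1)c1ncc(C(=O)C(F)(F)F)o1`, has not been measured. It differs from compound 2 by (trifluoromethyl)carbonyl in place of 4-methoxyphenyl on an aromatic carbon.

Compound 3 is expected to give a lower number than compound 2, a step of a 5.0-fold lower number from compound 2 to compound 3 (0.70 log units; beyond the scatter), beyond the scatter. The estimate for compound 3 in this assay is 20 nM, within 4 nM to 100 nM.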

Compound 3, inhibition constant: 4 nM
The estimate for compound 3 lay 5.0-fold (0.70 log units) above the measured number, and the stated range covers the measured number.
By their numbers in this assay, from the lowest: compound 3; then compound 1; then compound 2.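

At the aromatic carbon next to the ring oxygen, (trifluoromethyl)carbonyl in place of 4-methoxyphenyl gives a 25-fold lower number from compound 2 to compound 3 (1.40 log units; beyond the scatter) in this assay. This position therefore does not need a six-membered aromatic ring of carbon only to reach a low number, since a group with no ring serves here. No measurement bearing on the cause of this step is available.

Still open, going by these compounds, is whether a nitrile, a carboxylic acid or a plain acetyl at this position would match (trifluoromethyl)carbonyl. Also open, on these data alone, is whether the step would hold with a shorter chain on the shared core.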